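The source may report more compounds than this note shows. Statements on the series, on what has been measured and on what is new or still open speak of the compounds shown alone.

Three compounds have been measured so far:
compound 1, `Oc1ccc(C(c2c[nH]c3ccc(Br)cc23)c2c[nH]c3ccc(Br)cc23)cc1`, 3500 nM;
compound 2, `COc1ccc(C(c2c[nH]c3ccc(Br)cc23)c2c[nH]c3ccc(Br)cc23)cc1`, 2300 nM;
compound 3, `COc1ccc(C(c2c[nH]c3ccc(Br)cc23)c2c[nH]c3ccc(Br)cc23)cc1OC`, 7800 nM.

All three were tested in a functional assay on MCF7 cells (Homo sapiens) for inhibition, read by MTT assay, with a stated time of 48 h; a higher number here means a weaker inhibitor, a lower number a stronger inhibitor. Compound 3 stands at the highest number of the three; its nearest neighbour is compound 1 and its furthest is compound 2. The steps leading to it were a 2.2-fold higher number from compound 1 to compound 3 (0.35 log units; beyond the scatter) and a 3.4-fold higher number from compound 2 to compound 3 (0.53 log units; beyond the scatter), while a 1.5-fold lower number from compound 1 to compound 2 (0.18 log units; within the scatter).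

Compound 4, `Brc1ccc2[nH]cc(C(c3c[nH]c4ccc(Br)cc34)C3CCCCC3)c2c1`, has not yet been measured. It differs from compound 3 in one place: cyclohexyl in place of 3,4-dimethoxyphenyl on a saturated chain carbon bound to two aromatic carbons. Among the compounds with values here, none of the measured steps concerns this kind of change; they only swap hydrogen, methyl and methoxy around an aromatic ring, and in compound 3 the methoxy groups went with the highest number. Taking those groups away and trading the aromatic ring for a saturated one is new ground, so the expectation rests mainly on the spread of the three measured numbers. The expected step is a 2.0-fold lower number from compound 3 to compound 4 (0.29 log units; within the scatter), a modest move toward a lower number that may well stay within the scatter. Compound 4 is therefore estimated at 4000 nM, with a range from 1500 nM to 12000 nM.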

Compound 4, half-maximal inhibitory concentration: 4100 nM
Compound 4: middle estimate off by 1.0-fold (0.01 log units), on the low side; the range from low to high includes it.
By their numbers in this assay, from the lowest: compounds 2, 1, 4 and 3 (each within the scatter of the next, the first and the last beyond it).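

At the saturated chain carbon bound to two aromatic carbons, in this assay, an aromatic ring can give way to a saturated one without a change that stands out from the scatter: cyclohexyl replaces 3,4-dimethoxyphenyl (a 1.9-fold lower number from compound 3 to compound 4 (0.28 log units; within the scatter)), 4-methoxyphenyl (a 1.8-fold higher number from compound 2 to compound 4 (0.25 log units; within the scatter)) and 4-hydroxyphenyl (a 1.2-fold higher number from compound 1 to compound 4 (0.07 log units; within the scatter)). Among these four compounds, then, neither the aromatic ring nor the oxygen atoms of the leaving groups are needed to keep the number in this range, even though the earlier compounds had shown a step beyond the scatter among the aromatic groups themselves. Nothing measured here offers an explanation for this tolerance of the cyclohexyl swap.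

From the compounds shown here alone, what remains open is whether this place needs a ring at all, since a straight chain such as butyl could show how far the number depends on having any ring there. It is also unknown how the number would respond to an amine or a carboxylic acid attached to the cyclohexyl ring.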